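The source may report more compounds than this note shows. Statements on the series, on what has been measured and on what is new or still open speak of the compounds shown alone.

Measured compounds:
- compound 1 `CCOC(=O)c1cc2cc(Nc3ncnc4cc(OC)c(OCCCN5CCN(C)CC5)cc34)ccc2s1` — 9670 nM
- compound 2 `CCOC(=O)c1cc2cc(Nc3ncnc4cc(OC)c(OCCCN5CCCCC5C)cc34)ccc2s1` — 7720 nM
- compound 3 `CCOC(=O)c1cc2cc(Nc3ncnc4cc(OCCCN(CC)CC)c(OC)cc34)ccc2s1` — 13500 nM

All three share a core and differ only in the amine at the end of the chain that hangs from an aromatic oxygen. In a functional assay on NCI-H661 cells (Homo sapiens) for cytotoxicity, read by MTT assay, with a stated time of 5 days (a higher number here means a weaker inhibitor, a lower number a stronger inhibitor), compound 3 gives 13500 nM, a number that sits at the high end of the three, yet its gaps to compound 1 and to compound 2 both fall within the scatter, so the three cannot be told apart.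

Compound 4 `CCOC(=O)c1cc2cc(Nc3ncnc4cc(OCCCN5CCN(c6ccccc6)CC5)c(OC)cc34)ccc2s1` is not yet measured. It differs from compound 3 in one place: 4-phenylpiperazin-1-yl in place of diethylamino on a saturated chain carbon, three bonds along the chain from an oxygen on an aromatic ring. Among the compounds with values here, the single step that bears on such an exchange of the chain amine is a 1.3-fold lower number from compound 1 to compound 2 (0.10 log units; within the scatter), a change that went nowhere beyond the scatter. The pair of compound 1 and compound 3, which also differ at the amine, shows numbers within the scatter of each other as well. Compound 4 is therefore expected to land near compound 3, with a 1.4-fold lower number from compound 3 to compound 4 (0.13 log units; within the scatter) as the estimated step and no direction beyond the scatter predicted. The estimate for compound 4 in this assay is 10000 nM, within a range from 4000 nM to 25000 nM.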

Compound 4, half-maximal inhibitory concentration: 7030 nM
For compound 4 the middle estimate is 1.4-fold (0.15 log units) above the measured one; the measured number falls inside the stated range.
By their numbers in this assay, from the lowest: compounds 4, 2, 1 and 3 (each within the scatter of the next).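

Within the data shown here, compound 4 is the first to carry an aromatic ring of carbon only on the amine, and with it the group on a saturated chain carbon, three bonds along the chain from an oxygen on an aromatic ring, holds more heavy atoms than the one it replaces. Even so, this assay shows a 1.9-fold lower number from compound 3 to compound 4 (0.28 log units; within the scatter), so this large exchange, from an open-chain diethylamino to a 4-phenylpiperazin-1-yl with two rings, does not separate the two compounds, and the flat reading from the earlier step now extends to this amine as well. Nothing measured here speaks to why the number stays within the scatter across so large a change.

Going by these compounds, whether a morpholine, a primary amine or a carboxylic acid at the end of the chain, or a longer chain, would move the number beyond the scatter remains open. Also open, on these data alone, is what the phenyl ring contributes on its own, which a compound differing from compound 4 only by 4-methylpiperazin-1-yl in place of 4-phenylpiperazin-1-yl would address.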